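This account rests on a few compounds, and the source may have more. Where it says the series, first, only, none or still open, it means among the compounds named here.

Measured compounds in a physicochemical assay for lipophilicity; on this read-out lower numbers stand for lower lipophilicity and higher numbers for higher lipophilicity:
compound 1, `CC(/C=C/CC(C)CCCC(C)C)=C\C(=O)OC(C)C`, 7.15
compound 2, `CC(/C=C/CC(C)CCCC(C)(C)OC=O)=C\C(=O)OC(C)C`, 5.4
compound 3, `CCOC(C)(C)CCCC(C)C/C=C/C(C)=C/C(=O)OC(C)C`, 6.49

Compound 1 stands highest of the three. The nearest is compound 3, a number 0.66 log units lower from compound 1 to compound 3 (beyond the scatter); the furthest is compound 2, a number 1.75 log units lower from compound 1 to compound 2 (beyond the scatter). Between the two substituted chain compounds, a number 1.09 log units higher from compound 2 to compound 3 (beyond the scatter).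

Compound 4, `CC(/C=C/CC(C)CCCC(C)C)=C\C(=O)c1ccccc1`, is not yet measured in this assay. It differs from compound 1 as follows: phenyl in place of isopropoxy on a carbonyl carbon.

Going by the values given here, none of the measured steps bears directly on this change. All three involve a substituent on a saturated chain carbon or a swap of ethyl for formyl on an oxygen there, whereas the present change sits on the carbonyl carbon and removes the isopropoxy group. The chain of compound 1 is kept intact in compound 4. Without a comparable measured step, the expectation rests on the values of compound 1 alone: a step of no more than modest size is expected, most likely upward, a number 0.25 log units higher from compound 1 to compound 4 (within the scatter). Compound 4 is thus estimated at 7.4, within 6.8 to 8.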

Compound 4, partition coefficient: 7.26
Compound 4: middle estimate off by 0.14 log units, on the high side, within the range that was stated.
By their numbers in this assay, from the lowest: compound 2; then compound 3; then compounds 1 and 4 (each within the scatter of the next).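

In this assay, phenyl in place of isopropoxy on a carbonyl carbon gives a number 0.11 log units higher from compound 1 to compound 4 (within the scatter), the first step shown at this position. Six carbon atoms in an aromatic ring enter and a hydrogen-bond acceptor leaves, yet compounds 1 and 4 cannot be told apart on this read-out, whereas the substitutions on the saturated chain in compounds 2 and 3 both gave steps beyond the scatter. No supporting data bear on why this exchange leaves the two values so close.

One exchange at the carbonyl carbon cannot show whether other groups there, such as a dimethylamino group or a hydroxyl giving the carboxylic acid, would stay as close to compound 1. Also open, as far as these compounds go, is whether ethoxy or formyloxy on the chain would produce the same steps on the phenyl compound as on the isopropoxy compound.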